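A longer hydroxycarbamoyl chain on compound 1

The source may report more compounds than this note shows. Statements on the series, on what has been measured and on what is new or still open speak of the compounds shown alone.

Among the compounds with values here, in a functional assay on HEL cells (Homo sapiens) for inhibition, read by MTT assay, with a stated time of 48 h (on this read-out higher numbers stand for weaker inhibition and lower numbers for stronger inhibition), compound 1 `O=C(CCCOc1no[n+]([O-])c1S(=O)(=O)c1ccccc1)NO` gives 670 nM, the lowest of the three numbers measured so far. Compound 2 `O=C(CCCCCCCOc1no[n+]([O-])c1S(=O)(=O)c1ccccc1)NO` gives 10800 nM, and compound 3 `CC(C)(COc1no[n+]([O-])c1S(=O)(=O)c1ccccc1)C(=O)NO` gives 5010 nM. Compound 4 `O=C(NO)OCCOCCOc1no[n+]([O-])c1S(=O)(=O)c1ccccc1` has not yet been measured in this assay. It differs from compound 1 in one place, on a saturated chain carbon, two bonds along the chain from an oxygen on an aromatic ring: 2-((hydroxycarbamoyl)oxy)ethoxy in place of (hydroxycarbamoyl)methyl on a saturated chain carbon, two bonds along the chain from an oxygen on an aromatic ring.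

Within the data shown here, two measured steps bear on this change. Placing 4-(hydroxycarbamoyl)butyl where hydroxycarbamoyl stood gave a large step, a 16-fold higher number from compound 1 to compound 2 (1.21 log units; beyond the scatter). Placing 1-(hydroxycarbamoyl)-1-methylethyl where 2-(hydroxycarbamoyl)ethyl stood gave a modest one, a 7.5-fold higher number from compound 1 to compound 3 (0.87 log units; beyond the scatter). Among the measured compounds shown here, both changes moved the number upward, and no measured compound goes against that direction. The first step is the closer guide, since it too adds to the chain. For the measured compounds named here, no measured compound carries the 2-((hydroxycarbamoyl)oxy)ethoxy group, however, so the size of the step remains uncertain. A rise of modest to large size is therefore expected, and the expected step is a 4.5-fold higher number from compound 1 to compound 4 (0.65 log units; beyond the scatter). The estimate for compound 4 is 3000 nM, with an expected range from 800 nM to 12000 nM.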

Compound 4, half-maximal inhibitory concentration: 3730 nM
Beside the measured number, compound 4's estimate is 1.2-fold (0.09 log units) below it, and the stated range covers the measured number.
By their numbers in this assay, from the lowest: compound 1; then compounds 4 and 3 (each within the scatter of the next); then compound 2.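

At this place, on a saturated chain carbon, two bonds along the chain from an oxygen on an aromatic ring, 2-((hydroxycarbamoyl)oxy)ethoxy gives a 5.6-fold higher number from compound 1 to compound 4 (0.75 log units; beyond the scatter) and so joins the other changes shown in leaving the number higher than that of compound 1, which no replacement shown has yet bettered. The same group also gives a 2.9-fold lower number from compound 2 to compound 4 (0.46 log units; beyond the scatter) when it stands in place of 5-(hydroxycarbamoyl)pentyl, which shows that lengthening the chain at this place need not carry the whole rise seen with the longest chain, and that the size of the rise depends on the group that enters. Nothing shown here bears on the reason for these differences in size.

The compounds shown leave open whether the oxygens in the 2-((hydroxycarbamoyl)oxy)ethoxy chain or its length govern the step, a question that an all-carbon chain of the same length would help to settle. Also open, as far as these compounds go, is whether a shorter chain, or an amine or a carboxylic acid at the chain end in place of hydroxycarbamoyl, would give a lower number on the same core than compound 1, which gives 670 nM.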